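Chloro to methyl on the anilide ring: cytotoxicity notes

The source may hold more compounds than are shown below. What is called first, only, known or untested is meant among the compounds shown, and "the series" means these compounds.

Compound 3 `Cc1ccc(NC(=O)CSc2nccn2-c2ccc(Cl)cc2)c(Br)c1` gives 221000 nM in an ADME assay on MT4 cells (Homo sapiens) for cytotoxicity, read by MTT assay (on this read-out lower numbers stand for higher toxicity in this test and higher numbers for lower toxicity in this test), while compound 1 `Cc1ccc(-n2ccnc2SCC(=O)Nc2ccc(C)cc2Br)cc1` gives 80800 nM. The change between them, (methyl in place of chloro on an aromatic carbon), produced a step of a 2.7-fold lower number from compound 3 to compound 1 (0.44 log units; beyond the scatter). Compound 2 `O=C(CSc1nccn1-c1cccc2ccccc12)Nc1ccccc1Cl` gives 35200 nM in this assay; the difference between the cores of compound 2 and compound 3 is not broken down here. Compound 4 `Cc1ccccc1NC(=O)CSc1nccn1-c1cccc2ccccc12` awaits measurement in this assay. From compound 2 to compound 4 the change is methyl in place of chloro on an aromatic carbon. This is the same kind of change as from compound 3 to compound 1, though there the methyl sits para to a large group and here ortho to a large group. A similar downward step is expected because a 2.7-fold lower number from compound 3 to compound 1 (0.44 log units; beyond the scatter) went that way, so the expected step is a 2.0-fold lower number from compound 2 to compound 4 (0.29 log units; within the scatter), with wider uncertainty owing to the different place. Compound 4 is therefore expected to give 18000 nM, estimated between 7000 nM and 45000 nM.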

Compound 4, half-maximal cytotoxic concentration: 34600 nM
Estimate against measurement, compound 4: 1.9-fold (0.28 log units) below, within the range that was stated.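

In this assay the change from chloro to methyl gives a 1.0-fold lower number from compound 2 to compound 4 (0.01 log units; within the scatter), so on this core the swap leaves the read-out within the scatter. The step does not carry over in size from one core to the other: the same change on two cores in this assay, a 2.7-fold lower number (0.44 log units; beyond the scatter) from compound 3 to compound 1 and a 1.0-fold lower number (0.01 log units; within the scatter) from compound 2 to compound 4, 2.7-fold (0.43 log units) apart, beyond the scatter of two such steps. These two pairs show that the step cannot be assumed to transfer within this series, but they do not separate the effect of the core from that of the place, here ortho to a large group, and they give no rule for other cores.

Open, going by these compounds, is how a fluoro or a methoxy group at the same place on the core of compound 2 would read in this assay. Also open, on these data alone, is whether the chloro to methyl step on a third core would resemble either step seen so far.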